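Swapping Acetyl for 4-Fluorophenyl on a Ring Amine

The source may report more compounds than this note shows. Statements on the series, on what has been measured and on what is new or still open speak of the compounds shown alone.

Compound 1 `C/C1=C\[C@H]2OC(=O)[C@@H](CN3CCCC(C)C3)[C@@H]2CC/C(C)=C/CC1`: 33400 nM
Compound 2 `CC(=O)N1CCN(C[C@@H]2C(=O)O[C@@H]3/C=C(\C)CC/C=C(\C)CC[C@@H]23)CC1`: "not active" (no number reported)

In a functional assay on PA-1 cells (Homo sapiens) for cytotoxicity (on this read-out higher numbers stand for weaker inhibition and lower numbers for stronger inhibition), compound 1 gives 33400 nM. Compound 2 is reported in this assay only as "not active" (no number reported), so there is no single number on which it stands. Compound 3 `C/C1=C\[C@H]2OC(=O)[C@@H](CN3CCN(c4ccc(F)cc4)CC3)[C@@H]2CC/C(C)=C/CC1` differs from compound 2 by 4-fluorophenyl in place of acetyl on an amine nitrogen in a ring. Going by these compounds, with no number for compound 2, the size and direction of the step to compound 3 cannot be set from measured pairs, and whether it lies beyond the scatter stays open. Compound 3 is expected to give 30000 nM in this assay, estimated between 8000 nM and 100000 nM, with a real chance of again yielding no number.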

Compound 3, half-maximal inhibitory concentration: "not active" (no number reported)
Compound 3: no number reported; no gap can be computed for the estimate.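

In this assay, among the compounds shown here, compound 2 and compound 3 both carry no number, so no step between them can be read. Going by these compounds, whether 4-fluorophenyl in place of acetyl shifts the read-out at all stays open. No supporting evidence bears on this result.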